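Bromo in place of nitro: expectation for compound 4

The source may report more compounds than this note shows. Statements on the series, on what has been measured and on what is new or still open speak of the compounds shown alone.

The series shares one core, carried in compound 1 `O=C(/C=C\c1ccccc1[N+](=O)[O-])N1N=C(c2ccncc2)OC1c1c[nH]c2ccccc12`, compound 2 `O=C(/C=C\c1ccc([N+](=O)[O-])cc1)N1N=C(c2ccncc2)OC1c1c[nH]c2ccccc12` and compound 3 `Cc1ccc(/C=C\C(=O)N2N=C(c3ccncc3)OC2c2c[nH]c3ccccc23)cc1`, and is read in an ADME assay on PANC-1 cells (Homo sapiens) for cytotoxicity, read by MTT assay, with a stated time of 48 h; on this read-out lower numbers stand for stronger inhibition of growth and higher numbers for weaker inhibition of growth. Compound 1 reaches only the limit of the assay, giving > 30 ug/mL rather than a number. Compound 2 likewise stops at the limit, giving > 30 ug/mL. Compound 3 also stops at the limit, giving > 30 ug/mL. Compound 2 thus stands at the same limit as the two other values shown, as the limit of > 30 ug/mL in this assay, at which 3 of the 3 values shown sit, records. The steps a step that the two limits leave unreadable from compound 1 to compound 2, a step that the two limits leave unreadable from compound 1 to compound 3 and a step that the two limits leave unreadable from compound 2 to compound 3 are all hidden by these limits, so neither the move of the nitro group nor its exchange for methyl can be sized.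

Compound 4 `O=C(/C=C\c1ccc(Br)cc1)N1N=C(c2ccncc2)OC1c1c[nH]c2ccccc12` differs from compound 2 by bromo in place of nitro on an aromatic carbon. Within the data shown here, no measured step bears readably on this change; the nearest, a step that the two limits leave unreadable from compound 2 to compound 3, is unreadable. Compound 4 is therefore expected to sit at the limit as well, with the step that the limit leaves unreadable from compound 2 to compound 4 estimated as nothing beyond the scatter. The estimate for compound 4 is 45 ug/mL, between 15 ug/mL and 120 ug/mL.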

Compound 4, concentration for 50% growth inhibition: > 30 ug/mL
Compound 4 gave a limit, no number; the forecaster's own chance of this, stated with the estimate: 80%; the middle value does not contradict the limit.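

In this assay compound 4 gives only a limit, so none of its steps from compound 1, compound 2 or compound 3 can be read: the limit of > 30 ug/mL in this assay, at which 4 of the 4 values shown sit. The compounds shown leave open how nitro, methyl and bromo compare, and whether any such group on this core gives a numerical growth inhibition value.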